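Cytotoxicity notes: thiophene for phenyl on a methylated core

The source may hold more compounds than are shown below. What is called first, only, known or untested is meant among the compounds shown, and "the series" means these compounds.

Compound 1 `c1ccc(CCSCc2cnc3ccc(-c4ccccc4)cn23)cc1`: 9.9 ug/mL
Compound 2 `Cc1cc(-c2ccsc2)c2ncc(CSCCc3ccccc3)n2c1`: > 50 ug/mL
Compound 3 `Cc1cc(-c2ccccc2)cn2c(CSCCc3ccccc3)cnc12`: 31 ug/mL

In an ADME assay on HEL cells (Homo sapiens) for cytotoxicity, with a stated time of 3 days (a lower number here means that less compound is tolerated, a higher number that more compound is tolerated), compound 3 gives 31 ug/mL, the highest of the two numbers shown; its nearest neighbour is compound 1 with 9.9 ug/mL. Within the data shown here, the only measured step in the set, a 3.1-fold higher number from compound 1 to compound 3 (0.50 log units; beyond the scatter), separates these two. Compound 2 gives > 50 ug/mL, which is a limit of this assay rather than a number; one of the three values sits at that limit (the limit of > 50 ug/mL in this assay, at which 1 of the 3 values shown sits).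

Compound 4 `Cc1cc(-c2ccsc2)cn2c(CSCCc3ccccc3)cnc12` differs from compound 3 by thiophen-3-yl in place of phenyl on an aromatic carbon. Among the measured compounds shown here, no measured step covers this exchange; the methyl step from compound 1 to compound 3 does not bear on it. For the measured compounds named here, with no direct precedent, the expectation for this assay is a value near that of compound 3, or somewhat higher, with the outcome reaching the limit a real possibility. Compound 4 is therefore estimated at 40 ug/mL, within 15 ug/mL to 100 ug/mL. The expected step is a 1.3-fold higher number from compound 3 to compound 4 (0.11 log units; within the scatter), not clearly beyond the scatter.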

Compound 4, half-maximal cytotoxic concentration: > 50 ug/mL
Compound 4: no number, only a limit; the forecaster's own chance of this, stated with the estimate: 40%; middle value at least 1.2-fold (0.09 log units) from the limit.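

Thiophen-3-yl in place of phenyl on this aromatic carbon, meta to a methyl group, is the only exchange of this ring shown, and in this assay the number does not come down: an at least 1.6-fold higher number from compound 3 to compound 4 (0.20 log units; that floor lies within the scatter). Compound 4 gives > 50 ug/mL, which is a limit of the assay and not a number, so a rise beyond the scatter is neither shown nor excluded. Both compounds carrying thiophen-3-yl, compound 2 and compound 4, now sit at that ceiling: the limit of > 50 ug/mL in this assay, at which 2 of the 4 values shown sit.

On these data alone, how far compound 4 lies past the limit stays open, and so does the true size of this exchange. Also open, as far as these compounds go, is whether thiophen-3-yl gives the same reading without the methyl group, and how an amine or a carboxylic acid on this carbon would read.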